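The compounds below may be only part of what the source reports. "The series", "measured", "known", "first", "only" and "open" are said of these compounds alone.

In an ADME assay on HEK293 cells (Homo sapiens) for cytotoxicity, read by resazurin assay, with a stated time of 48 h (on this read-out lower numbers stand for higher toxicity in this test and higher numbers for lower toxicity in this test), compound 1 `COc1ccc(S(=O)(=O)Nc2ccc(-c3nc4ccccc4o3)cc2)cc1` reaches only the limit of the test, > 100000 nM. Two other members of the series give numbers: compound 3 `O=S(=O)(Nc1ccc(-c2nc3ccccc3o2)cc1)c1ccc(C(F)(F)F)cc1` gives 94000 nM, and compound 2 `Cc1ccccc1S(=O)(=O)Nc1ccc2oc(-c3ccccc3)nc2c1` gives 57000 nM. Compound 4 `O=S(=O)(Nc1ccc(-c2nc3ccccc3o2)cc1)c1ccccc1F` is compound 1 with 2-fluorophenyl in place of 4-methoxyphenyl on a sulfonyl sulfur. For the measured compounds named here, the one measured step that resembles this change, an at least 1.0-fold lower number from compound 1 to compound 3 (0.02 log units; that floor lies within the scatter), moved the read-out by nothing beyond the scatter. A similar outcome is therefore expected in this assay, so the step of a number no higher from compound 1 to compound 4 (the limit leaves the size open) is expected to stay within the scatter. Compound 4 is estimated at 100000 nM, with a range from 50000 nM to 200000 nM, and it may again give only a limit rather than a number.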

Compound 4, half-maximal cytotoxic concentration: > 100000 nM
Compound 4: a limit, no number; the forecaster's own chance of this, stated with the estimate: 45%; the middle value sits exactly at the limit.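

For the compounds shown here, compound 1 and compound 4 both give only a limit, not a number, so no step between them can be read: the limit of > 100000 nM in this assay, at which 2 of the 4 values shown sit. In this assay the compounds shown leave open whether 2-fluorophenyl and 4-methoxyphenyl on a sulfonyl sulfur differ at all.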